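Aromatic group exchange on compound 2

This account rests on a few compounds, and the source may have more. Where it says the series, first, only, none or still open, it means among the compounds named here.

Of the compounds shown here, two have been measured so far. In a functional assay on SNU-423 cells (Homo sapiens) for inhibition, read by MTT assay, with a stated time of 72 h (on this read-out higher numbers stand for weaker inhibition and lower numbers for stronger inhibition), compound 1 (`Nc1ncnc2c1c(-c1cnc3[nH]ccc3c1)nn2CCCCCCCCC(=O)NO`) gives 7500 nM as its half-maximal inhibitory concentration. Compound 2 (`Nc1ncnc2c1c(-c1cnc3[nH]ccc3c1)nn2CCCCCCC(=O)NO`) gives 7500 nM in this assay and stands level with compound 1 at the digits available.

The next structure is compound 3 (`Nc1nc2cc(-c3nn(CCCCCCC(=O)NO)c4ncnc(N)c34)ccc2o1`), which keeps the chain of compound 2 and alters the aromatic group. The difference is a group of 10 heavy atoms (7 carbon, 2 nitrogen, 1 oxygen; one five-membered aromatic ring with 2 hetero atoms, one six-membered aromatic ring of carbon only) in place of a group of 9 heavy atoms (7 carbon, 2 nitrogen; one five-membered aromatic ring with 1 hetero atom, one six-membered aromatic ring with 1 hetero atom), on an aromatic carbon and the entering group is 2-amino-1,3-benzoxazol-5-yl.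

For the measured compounds named here, the only measured step is no change at the digits printed from compound 1 to compound 2 (within the scatter) and it lies in the chain, with the aromatic group untouched. It therefore says nothing direct about this exchange. Going by the values given here, it shows only that both compounds sit at the same level, which serves as the starting point. Among the compounds with values here, no measured step covers an aromatic exchange, so the expectation is loose: a modest move toward stronger inhibition, with no change beyond the scatter also plausible.

The estimated step is a 2.1-fold lower number from compound 2 to compound 3 (0.33 log units; beyond the scatter) and it carries wide uncertainty. Compound 3 is expected at 3500 nM in this assay with an estimated range of 800 nM to 12000 nM for now.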

Compound 3, half-maximal inhibitory concentration: 6100 nM
Beside the measured number, compound 3's estimate is 1.7-fold (0.24 log units) below it; low and high end bracket the measured number.
By their numbers in this assay, from the lowest: compounds 3, 1 and 2 (each within the scatter of the next).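

In this assay, for the compounds shown here, the exchange on the aromatic carbon of the five-membered aromatic ring with 2 nitrogen, where 2-amino-1,3-benzoxazol-5-yl enters, gives a 1.2-fold lower number from compound 2 to compound 3 (0.09 log units; within the scatter) and is the first reading at this position. Together with no change at the digits printed from compound 1 to compound 2 (within the scatter) in the chain, it means that one change at each of two places on the series has left the read-out within the scatter, and here that holds even though a six-membered aromatic ring of carbon only replaces one with a hetero atom and an oxygen enters the five-membered ring. No supporting data bear on this result.

On these data alone, it remains open whether a different kind of group on this aromatic carbon, such as a plain phenyl ring or one carrying a carboxylic acid, would move the number beyond the scatter. As far as these compounds go, it is equally open whether 2-amino-1,3-benzoxazol-5-yl would read the same on the longer chain of compound 1 or on a shorter chain than that of compound 2.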